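Swapping the Pyridine for Phenyl in a Cytotoxic Series

The source may hold more compounds than are shown below. What is called first, only, known or untested is meant among the compounds shown, and "the series" means these compounds.

Compound 1 `O=C(CN1CCN(c2nnc(Cc3ccncc3)c3ccccc23)CC1)Nc1cccc(F)c1` is tested in a functional assay on MDA-MB-231 cells (Homo sapiens) for cytotoxicity, read by MTT assay, with a stated time of 72 h (on this read-out higher numbers stand for weaker inhibition and lower numbers for stronger inhibition), where compound 1 gives 4.4 nM, the lowest of the three numbers shown. Compound 2 `O=C(CN1CCN(c2nnc(Cc3ccncc3)c3ccccc23)CC1)Nc1ccc(Br)cc1` gives 19 nM, and compound 3 `O=C(CN1CCN(c2nnc(Cc3ccncc3)c3ccccc23)CC1)Nc1c(F)cccc1F` gives 1900 nM. Each of those differences concerns the ring on the amide-type nitrogen: a 4.3-fold higher number from compound 1 to compound 2 (0.64 log units; beyond the scatter), a 430-fold higher number from compound 1 to compound 3 (2.64 log units; beyond the scatter), and a 100-fold higher number from compound 2 to compound 3 (2.00 log units; beyond the scatter). Compound 4 `O=C(CN1CCN(c2nnc(Cc3ccccc3)c3ccccc23)CC1)Nc1cccc(F)c1` alters a different place: phenyl in place of pyridin-4-yl on a saturated chain carbon bound to an aromatic carbon. Among the compounds with values here, none of the measured steps touches this position, so they give no direct guide to the size or direction of the change. The expectation is therefore only a modest step, a 2.0-fold higher number from compound 1 to compound 4 (0.31 log units; beyond the scatter). Compound 4 is estimated at 9 nM, within a range from 2 nM to 45 nM.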

Compound 4, half-maximal inhibitory concentration: 3730 nM
For compound 4 the middle estimate is 410-fold (2.62 log units) below the measured one, and the stated range ends below it.
By their numbers in this assay, from the lowest: compound 1; then compound 2; then compounds 3 and 4 (each within the scatter of the next).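

Putting phenyl in place of pyridin-4-yl on a saturated chain carbon bound to an aromatic carbon gives an 850-fold higher number from compound 1 to compound 4 (2.93 log units; beyond the scatter) in this assay. The earlier large steps all came from the ring on the amide-type nitrogen, so this position is now also shown to be sensitive, even though the swap only replaces one ring nitrogen with carbon and keeps the heavy-atom count. No available evidence accounts for this step. Going by these compounds, whether pyridin-3-yl or a piperidine ring on the same carbon would keep the low number of compound 1 remains open. So does whether this swap would have the same size alongside the 4-bromophenyl of compound 2.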